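Aryl swaps level so far, pyridin-2-yl next

This account rests on a few compounds, and the source may have more. Where it says the series, first, only, none or still open, it means among the compounds named here.

In a functional assay on B16-F10 cells (Mus musculus) for cytotoxicity (a lower number here means a stronger inhibitor, a higher number a weaker inhibitor), compound 1 `O=c1oc2ccccc2c2nc3c(ccc4cc[nH]c43)c(-c3cccc4ccccc34)c12` gives 70700 nM and compound 2 `O=c1oc2ccccc2c2nc3c(ccc4cc[nH]c43)c(-c3cccc(Br)c3)c12` gives 70700 nM while compound 3 `O=c1oc2ccccc2c2nc3c(ccc4cc[nH]c43)c(-c3ccc(Br)cc3)c12` gives 70700 nM and so stands level with both. The next change leads to compound 4 `O=c1oc2ccccc2c2nc3c(ccc4cc[nH]c43)c(-c3ccccn3)c12` with pyridin-2-yl in place of 4-bromophenyl on an aromatic carbon. The measured swaps at this position bear on it (no change at the digits printed from compound 1 to compound 2 (within the scatter); no change at the digits printed from compound 1 to compound 3 (within the scatter); no change at the digits printed from compound 2 to compound 3 (within the scatter)), and none lies beyond the scatter. None of them brings a hetero atom into this ring, so the support is indirect. The step expected in this assay is a 1.1-fold lower number from compound 3 to compound 4 (0.04 log units; within the scatter) with no step beyond the scatter and no direction favoured. For compound 4 the estimated value is 65000 nM with an expected range from 25000 nM to 100000 nM for now.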

Compound 4, half-maximal inhibitory concentration: 70700 nM
Compound 4: the middle estimate sits 1.1-fold (0.04 log units) below what was measured; measured number inside the range.
By their numbers in this assay, from the lowest: compounds 1, 2, 3 and 4 (each within the scatter of the next).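

In this assay pyridin-2-yl puts a ring nitrogen and a hydrogen-bond acceptor on this aromatic carbon, which none of the earlier groups did, and the readings show no change at the digits printed from compound 3 to compound 4 (within the scatter) and no change at the digits printed from compound 2 to compound 4 (within the scatter) and no change at the digits printed from compound 1 to compound 4 (within the scatter) in turn. The level reading at this position therefore now covers one aromatic ring with a hetero atom as well as the carbon-only aryl groups, though only across these four compounds.

On these data alone, whether a non-aromatic group at this position, such as an amine or a carboxylic acid, would read differently stays open. Nothing measured alongside these values accounts for the level readings.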